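The source may hold more compounds than are shown below. What is called first, only, known or untested is meant among the compounds shown, and "the series" means these compounds.

The compounds measured so far, with their values:

Compound 1, `CCc1ccc(C(=O)/C=C/C(=O)O)cc1`: 21000 nM
Compound 2, `CCc1ccc(C(C)C)cc1C(=O)/C=C/C(=O)O`: 5940 nM
Compound 3, `CCc1c(C(=O)/C=C/C(=O)O)cc(C(C)C)cc1C(C)C`: 12400 nM

In a functional assay on LS174T cells (Homo sapiens) for inhibition, read by MTT assay, with a stated time of 72 h (a higher number here means a weaker inhibitor, a lower number a stronger inhibitor), compound 1 stands at the highest of the three numbers. Its nearest neighbour is compound 3, whose value lies within the scatter of that of compound 1, so the two cannot be told apart. Compound 2 sits furthest away, beyond the scatter on the lower side, and is the only one of the three clearly separated from compound 1.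

A single step between measured compounds has been recorded: a 2.1-fold higher number from compound 2 to compound 3 (0.32 log units; beyond the scatter). It adds a branched alkyl group to the core and is described as modest.

Compound 4, `O=C(O)/C=C/C(=O)c1ccccc1`, is the next compound to be examined in this assay. It differs from compound 1 in one place: hydrogen in place of ethyl on an aromatic carbon

The recorded step concerns a different group at a different place, so it bears only loosely on this change. Its modest size, together with the small spread among compounds 1 and 3, suggests no large movement. Compound 4 is therefore expected to give a step of a 1.2-fold higher number from compound 1 to compound 4 (0.08 log units; within the scatter), which would keep it near compound 1. The estimate for compound 4 is 25000 nM, with a range from 10000 nM to 60000 nM.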

Compound 4, half-maximal inhibitory concentration: 45500 nM
For compound 4 the middle estimate is 1.8-fold (0.26 log units) below the measured one, within the range that was stated.
By their numbers in this assay, from the lowest: compound 2; then compounds 3 and 1 (each within the scatter of the next); then compound 4.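

In this assay, hydrogen in place of ethyl on the aromatic carbon para to a group of 7 heavy atoms gives a 2.2-fold higher number from compound 1 to compound 4 (0.34 log units; beyond the scatter), a modest step but one beyond the scatter, so compound 1 is the stronger inhibitor of this pair. For the compounds shown here, this is the first evidence that the ethyl group at this position makes a measurable difference, and here the alkyl-bearing compound has the lower number. The earlier step ran the other way with respect to alkyl substitution, since isopropyl in place of hydrogen gave a 2.1-fold higher number from compound 2 to compound 3 (0.32 log units; beyond the scatter), so compound 3 goes against any general rule that an added alkyl group lowers the number, and the effect of such a group depends on the pair examined; nothing available accounts for either step.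

The compounds shown leave open whether the step follows from the size of the group at this position, as a methyl group or a longer chain such as propyl would show. They also leave open whether a group of another kind there, such as a methoxy group or an amine, would keep the number of compound 1 or move it further.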